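Replacing an Aminopropylamino Chain with a Sulfonate Ester

The compounds below may be only part of what the source reports. "The series", "measured", "known", "first", "only" and "open" are said of these compounds alone.

In a functional assay on HCT-116 cells (Homo sapiens) for cytotoxicity, read by MTT assay, with a stated time of 72 h (a lower number here means a stronger inhibitor, a higher number a weaker inhibitor), compound 1 `N[C@H]1CC[C@H](Nc2c(C(=O)NCc3ccc(F)cc3)nc(N3CCCCS3(=O)=O)c3cccnc23)CC1` reaches only the assay limit, > 10000 nM; this is the limit of > 10000 nM in this assay, at which 1 of the 2 values shown sits. For the measured compounds named here, compound 2 `NCCCNc1c(C(=O)NCc2ccc(F)cc2)nc(Br)c2cccnc12` gives 18000 nM in this assay, the only numbered value in this small set. Compound 3 `Cc1ccc(S(=O)(=O)Oc2c(C(=O)NCc3ccc(F)cc3)nc(Br)c3cccnc23)cc1` differs from compound 2 by one change: ((4-methylphenyl)sulfonyl)oxy in place of (3-aminopropyl)amino on an aromatic carbon. Going by the values given here, no measured pair shows a comparable change, so the size of the step is open. The step of a 1.1-fold higher number from compound 2 to compound 3 (0.05 log units; within the scatter) is expected to stay within the usual scatter, with compound 3 remaining weak. Compound 3 is therefore estimated at 20000 nM, between 5000 nM and 80000 nM.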

Compound 3, half-maximal inhibitory concentration: > 20000 nM
Compound 3 gave a limit, no number (the forecaster's own chance of this, stated with the estimate: 50%); the middle value sits exactly at the limit.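

The reading for compound 3 is a limit of the assay and not a number: the limit of > 20000 nM in this assay, at which 1 of the 3 values shown sits. In this assay, the step is an at least 1.1-fold higher number from compound 2 to compound 3 (0.04 log units; that floor lies within the scatter), so this carbon, para to a bromo group, carries ((4-methylphenyl)sulfonyl)oxy in place of (3-aminopropyl)amino with no sign of a lower number. Going by these compounds, because only a floor is available, the true size of the step stays unknown, and it may be small or large.

On these data alone, it remains open whether a hydroxyl group or a carboxylic acid at this carbon would give a lower number.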